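This account rests on a few compounds, and the source may have more. Where it says the series, first, only, none or still open, it means among the compounds named here.

Measured compounds:
- compound 1, `C[C@@H]1O[C@H](C2CCCCC2)C([Si](C)(C)C)=C(Cl)[C@H]1C`, 20000 nM in a functional assay on SW1573 cells (Homo sapiens) for antiproliferative activity; a higher number here means a weaker inhibitor of growth, a lower number a stronger inhibitor of growth
- compound 2, `C[C@@H]1O[C@H](CCC=C(Br)Br)C([Si](C)(C)C)=C(Cl)[C@H]1C`, 22000 nM in this assay
- compound 3, `C#CCC[C@H]1O[C@@H](C)[C@H](C)C(Cl)=C1[Si](C)(C)C`, 19000 nM in this assay

Compound 3 gives the lowest of the three numbers, but its gaps to the others are small: a 1.1-fold lower number from compound 1 to compound 3 (0.02 log units; within the scatter) and a 1.2-fold lower number from compound 2 to compound 3 (0.06 log units; within the scatter), both within the scatter, so the three compounds cannot be told apart in this assay. Compound 4, `C=CCC[C@H]1O[C@@H](C)[C@H](C)C(Cl)=C1[Si](C)(C)C`, differs from compound 3 only at the end of the chain: vinyl in place of ethynyl on a saturated chain carbon, two bonds along the chain from a saturated ring carbon. Going by the values given here, no measured step reproduces this change exactly. The nearest is the step from compound 2 to compound 3, which exchanges one two-carbon end group for another at the same place on the chain: a 1.2-fold lower number from compound 2 to compound 3 (0.06 log units; within the scatter). The other step at the chain, a 1.1-fold higher number from compound 1 to compound 2 (0.04 log units; within the scatter), is likewise within the scatter. All three measured compounds sit together regardless of what is attached to the saturated ring carbon, so the exchange of ethynyl for vinyl is expected to give no step beyond the scatter, a 1.1-fold higher number from compound 3 to compound 4 (0.02 log units; within the scatter). Compound 4 is therefore estimated at 20000 nM, expected between 10000 nM and 40000 nM in this assay.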

Compound 4, concentration for 50% growth inhibition: 23000 nM
Compound 4: middle estimate off by 1.2-fold (0.06 log units), on the low side, and the stated range covers the measured number.
By their numbers in this assay, from the lowest: compounds 3, 1, 2 and 4 (each within the scatter of the next).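

Going by these compounds alone, exchanging the triple bond of ethynyl for the double bond of vinyl, on a saturated chain carbon two bonds along the chain from a saturated ring carbon, produces no step that this assay can resolve (a 1.2-fold higher number from compound 3 to compound 4 (0.08 log units; within the scatter)). The larger exchange at that place, from 2,2-dibromoethenyl to vinyl, is equally unresolved (a 1.0-fold higher number from compound 2 to compound 4 (0.02 log units; within the scatter)), as is but-3-en-1-yl in place of cyclohexyl on the saturated ring carbon (a 1.2-fold higher number from compound 1 to compound 4 (0.06 log units; within the scatter)), so all four compounds remain within the scatter of one another. No supporting measurement bears on this flat result.

From the compounds shown here alone, whether an amine, a carboxylic acid or a longer chain on the saturated ring carbon would produce a step beyond the scatter remains open. Going by these compounds, the four compounds also share the rest of their core, so the contribution of that shared part remains untested.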